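The source may hold more compounds than are shown below. What is called first, only, known or untested is meant among the compounds shown, and "the series" means these compounds.

Measured so far:
compound 1 `Cc1nc(S(C)(=O)=O)ccc1Oc1ncnc(OC2CCN(C(=O)OC(C)(C)C#N)CC2)c1F` — 1320 nM
compound 2 `Cc1nc(S(C)(=O)=O)ccc1Oc1ncnc(OC2CCN(C(=O)OC3(C(F)(F)F)COC3)CC2)c1F` — 342 nM

In a functional assay on isolated protein for inhibition of Glucose-dependent insulinotropic receptor (Rattus norvegicus), read by HTRF and cAMP accumulation (a higher number here means that more compound is needed for the effect, a lower number that less compound is needed), compound 1 gives 1320 nM, the highest of the two numbers, while compound 2 gives 342 nM; the step of a 3.9-fold lower number from compound 1 to compound 2 (0.59 log units; beyond the scatter) shows that altering the group in this part of the molecule can move the result modestly. Compound 3 `Cc1nc(S(C)(=O)=O)ccc1Oc1ncnc(OC2CCN(C(=O)SC(C)C)CC2)c1F` differs from compound 1 by isopropylsulfanyl in place of 1-cyano-1-methylethoxy on a carbonyl carbon. Among the measured compounds shown here, no measured step makes this kind of exchange, so the expectation rests only on compound 1 and the spread seen so far. A step no larger than a 1.5-fold lower number from compound 1 to compound 3 (0.17 log units; within the scatter) is expected, and compound 3 is estimated at 900 nM, between 300 nM and 2700 nM.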

Compound 3, half-maximal effective concentration: 41.3 nM
Estimate against measurement, compound 3: 22-fold (1.34 log units) above; the measured number lies below the stated range.
By their numbers in this assay, from the lowest: compound 3; then compound 2; then compound 1.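

In this assay, the group on the carbonyl carbon can move the number much further than the first two compounds showed: isopropylsulfanyl gives a 32-fold lower number from compound 1 to compound 3 (1.50 log units; beyond the scatter) and also an 8.3-fold lower number from compound 2 to compound 3 (0.92 log units; beyond the scatter) in comparison with the oxetane-bearing group. This change swaps the oxygen link for sulfur and also replaces the rest of the group, so both differences travel together. Nothing available explains the drop. The compounds shown leave open whether the sulfur or the isopropyl part matters more; an isopropoxy or isopropylamino group on the same carbonyl carbon would separate the two.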